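From 4-hydroxy-2-methylphenyl to 4-ethylphenyl on a shared core

The source may hold more compounds than are shown below. What is called first, only, known or untested is meant among the compounds shown, and "the series" means these compounds.

In a functional assay on NCI/ADR-RES cells (Homo sapiens) for inhibition, read by sulforhodamine B assay, with a stated time of 48 h (a lower number here means a stronger inhibitor of growth, a higher number a weaker inhibitor of growth), compound 1 (`Cc1ccc(C2=NN(c3ccc(S(C)(=O)=O)cc3)C(=O)CC2)cc1`) gives 270 nM, while compound 2 (`Cc1cc(O)ccc1C1=NN(c2ccc(S(C)(=O)=O)cc2)C(=O)CC1`) gives 3260 nM, the higher of the two numbers and so the weaker growth inhibition. Compound 3 (`CCc1ccc(C2=NN(c3ccc(S(C)(=O)=O)cc3)C(=O)CC2)cc1`) is still unmeasured. It differs from compound 2 in one place, on a carbon with a double bond to nitrogen, where 4-ethylphenyl stands in place of 4-hydroxy-2-methylphenyl: 4-ethylphenyl in place of 4-hydroxy-2-methylphenyl on a carbon with a double bond to nitrogen. Among the compounds with values here, one measured step bears on this change: a 12-fold higher number from compound 1 to compound 2 (1.08 log units; beyond the scatter), which brought in that same 4-hydroxy-2-methylphenyl in place of 4-methylphenyl. The entering 4-ethylphenyl, like the 4-methylphenyl of compound 1, has no hydroxy, so a large step the opposite way, to a lower number, is expected in this assay. The estimated change is an 11-fold lower number from compound 2 to compound 3 (1.04 log units; beyond the scatter). The expected value for compound 3 is 300 nM, within a range of 100 nM to 900 nM.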

Compound 3, concentration for 50% growth inhibition: 400 nM
Compound 3: the middle estimate sits 1.3-fold (0.12 log units) below what was measured; low and high end bracket the measured number.
By their numbers in this assay, from the lowest: compounds 1 and 3 (each within the scatter of the next); then compound 2.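

In this assay, a second group without a hydroxy gives the same picture as the first: an 8.2-fold lower number from compound 2 to compound 3 (0.91 log units; beyond the scatter), so compound 2 now stands apart from two neighbours at this position rather than one. Adding one methyl to the chain of compound 1 gives a 1.5-fold higher number from compound 1 to compound 3 (0.17 log units; within the scatter), which means that 4-methylphenyl and 4-ethylphenyl cannot be told apart here and that this position takes either group. Nothing available explains why the numbers fall as they do.

The compounds shown leave open which part of 4-hydroxy-2-methylphenyl goes with the higher number, the hydroxy or the added methyl, and a plain 4-hydroxyphenyl or 2-methylphenyl would separate the two. On these data alone, it also remains open whether a longer chain, such as 4-propylphenyl, or a 4-aminophenyl would keep the number of compound 3.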